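Removing a Methoxy Group From a Weak Cytotoxic Amide

The compounds below may be only part of what the source reports. "The series", "measured", "known", "first", "only" and "open" are said of these compounds alone.

Compound 1, `CNC(=O)c1cc(Oc2ccc(NC(=O)c3cc(-c4ccc(Cl)cc4)ncn3)cc2)ccn1`: > 100000 nM
Compound 2, `CNC(=O)c1cc(Oc2ccc(NC(=O)c3cc(-c4ccc(OC)cc4)ncn3)cc2F)ccn1`: 56200 nM
Compound 3, `CNC(=O)c1cc(Oc2ccc(NC(=O)c3nccc(-c4cccc(Cl)c4)n3)cc2)ccn1`: 20800 nM

Of the compounds shown here, three built on a shared core have been tested in a functional assay on PC-3 cells (Homo sapiens) for cytotoxicity, read by MTT assay, with a stated time of 72 h; a lower number here means a stronger inhibitor, a higher number a weaker inhibitor. For compound 1 the assay gave only a limit and no number, (the limit of > 100000 nM in this assay, at which 1 of the 3 values shown sits). Among the two actual numbers, compound 2 stands highest, with 56200 nM in this assay. Its nearest neighbour is compound 3, which gives 20800 nM in this assay, a gap that lies beyond the usual scatter, so compound 3 is the weaker inhibitor by a small but real margin. All three are weak inhibitors in this assay.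

The next compound, compound 4, `CNC(=O)c1cc(Oc2ccc(NC(=O)c3cc(-c4ccccc4)ncn3)cc2F)ccn1`, differs from compound 2 in one place: hydrogen in place of methoxy on an aromatic carbon. Put another way, the 4-methoxyphenyl group becomes a plain phenyl group. Among the compounds with values here, no measured pair in this set shows what that change does to the read-out, so the step from compound 2 to compound 4 in this assay cannot be read from neighbours. Given that every compound here sits in the weak range, the expectation is a step of no more than the scatter, in either direction, a 1.2-fold higher number from compound 2 to compound 4 (0.06 log units; within the scatter). Compound 4 is accordingly estimated at 65000 nM in this assay, in a range from 25000 nM to 200000 nM.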

Compound 4, half-maximal inhibitory concentration: 44300 nM
For compound 4 the middle estimate is 1.5-fold (0.17 log units) above the measured one, within the range that was stated.
By their numbers in this assay, from the lowest: compound 3; then compounds 4 and 2 (each within the scatter of the next). At a limit, above all of these: compound 1.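

In this assay, within the data shown here, hydrogen in place of methoxy on an aromatic carbon gives the first one-place step in this set (a 1.3-fold lower number from compound 2 to compound 4 (0.10 log units; within the scatter)), and the pair cannot be told apart by this read-out. On this aromatic carbon, para to a large group, the presence or absence of the methoxy group, with its one carbon and one oxygen, makes no difference that this measurement can detect, so the plain phenyl group and the 4-methoxyphenyl group both belong to the same weak range. Nothing measured among these compounds speaks to the reason for this result.

On these data alone, whether a much different group on this same carbon, such as an amine, a carboxylic acid or a longer chain like butoxy, would give a clearly lower number remains open, as a single replacement by hydrogen says nothing about those groups. Compound 1 and compound 3 each differ from compound 2 and compound 4 in more than one place, so the steps among them cannot be read, and this one step is all that the set offers about this position.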